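From carboxy to phenylcarbamoyl in compound 4

The source may report more compounds than this note shows. Statements on the series, on what has been measured and on what is new or still open speak of the compounds shown alone.

Measured in an ADME assay on MRC5 cells (Homo sapiens) for inhibition, with a stated time of 72 h; a higher number here means that more compound is needed for the effect, a lower number that less compound is needed
- compound 1 `CO[C@H]1CC[C@H](NC(=O)c2n[nH]cc2NC(=O)c2c(C)nc3ccccn23)CC1` gives 34000 nM
- compound 2 `COc1cccc(OC)c1C(=O)Nc1c[nH]nc1C(=O)O` gives > 50000 nM (a limit)
- compound 3 `CO[C@H]1CC[C@H](NC(=O)c2n[nH]cc2NC(=O)c2cc(Cl)cc(Cl)c2)CC1` gives 13000 nM

Compound 2 stands at > 50000 nM in this assay, which is a limit of the assay and not a number. Its place among the three compounds is therefore known only as that limit.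

Compound 4 `COc1cccc(OC)c1C(=O)Nc1c[nH]nc1C(=O)Nc1ccccc1` differs from compound 2 in one place (anilino in place of hydroxy on a carbonyl carbon). The same difference reads as carboxy to phenylcarbamoyl. Among the measured compounds shown here, no measured pair shows this change, so any step in this assay remains an expectation. Neither compound 1 (34000 nM) nor compound 3 (13000 nM) carries the carboxy group, and both return numbers rather than a limit. On that basis, a moderate move toward a lower number is expected, with the estimated step being an at least 2.2-fold lower number from compound 2 to compound 4 (0.35 log units; beyond the scatter) (its true size is uncertain while the starting point is a limit). The estimate for compound 4 is 22000 nM (expected range 7000 nM to 50000 nM).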

Compound 4, half-maximal effective concentration: > 50000 nM
Compound 4 ended at the assay's limit (the forecaster's own chance of this, stated with the estimate: 30%); at least 2.2-fold (0.35 log units) between middle value and limit.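

In this assay compound 2 and compound 4 both stand at a limit and not at a number, so no step can be read between them. The compounds shown leave open whether anilino in place of hydroxy on a carbonyl carbon changes the value at all, and in which direction.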